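Bromo to Chloro on the Phenyl Ring

A few compounds are considered here, and "the series" means these few. Any claim that something is new, unique, unknown or untested is made for them only; others in the source may bear on it.

The series shares one core, seen in compound 1 `Cc1nnc(SCC(=O)N/N=c2/scc(-c3ccc(F)cc3)n2-c2ccccc2)s1`, in which the para substituent of the outer phenyl ring is varied. In a functional assay on C6 cells (Rattus norvegicus) for cytotoxicity, read by MTT assay, with a stated time of 24 h (a higher number here means a weaker inhibitor, a lower number a stronger inhibitor), compound 1 gives 27.3 ug/mL. Compound 2 `Cc1nnc(SCC(=O)N/N=c2/scc(-c3ccc(Br)cc3)n2-c2ccccc2)s1` carries bromo at that position, but in this assay compound 2 has "not determined" (no result reported), so no number stands for it and it offers no anchor of its own. Compound 3 `Cc1nnc(SCC(=O)N/N=c2/scc(-c3ccc(Cl)cc3)n2-c2ccccc2)s1` differs from compound 2 by chloro in place of bromo on an aromatic carbon. Going by the values given here, since the only measured value belongs to compound 1, and a halogen exchange of this kind is usually a small matter, the step expected between compound 2 and compound 3 in this assay is none beyond the usual scatter, with no direction foreseen. On that basis compound 3 is expected to give about 25 ug/mL in this assay, with an estimated range from 10 ug/mL to 60 ug/mL.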

Compound 3, half-maximal inhibitory concentration: 28 ug/mL
Compound 3: the middle estimate sits 1.1-fold (0.05 log units) below what was measured; measured number inside the range.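

Compound 3 gives this position its first readable comparison: swapping fluoro for chloro at this place yields a 1.0-fold higher number from compound 1 to compound 3 (0.01 log units; within the scatter) in this assay and so leaves the two compounds indistinguishable. At this place, para to a large group, the fluoro and chloro compounds therefore cannot be told apart by this read-out. Nothing in the available evidence explains this result.

From the compounds shown here alone, the step from bromo to chloro cannot be read, since compound 2 has no number, so it remains unknown whether the bromo compound would read like the other two. Also open, going by these compounds, is whether a group of another kind at this place, such as an amine, a carboxylic acid or a longer chain, would move the number beyond the usual scatter.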